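A few compounds are considered here, and "the series" means these few. Any claim that something is new, unique, unknown or untested is made for them only; others in the source may bear on it.

Within the data shown here, in a physicochemical assay for solubility, in phosphate buffer, at pH 6.8 (on this read-out higher numbers stand for higher solubility and lower numbers for lower solubility), three compounds have numbers so far. Compound 1 (`CCC(CC)C1C(C(=O)c2ccc(OC)cc2)=C(O)C(=O)N1c1ccc(-c2ccon2)cc1`) gives 2200 nM. Compound 2 (`COc1ccccc1C1C(C(=O)C(C)(C)C)=C(O)C(=O)N1c1ccc(-c2ccon2)cc1`) gives 29600 nM, the highest of the three. Compound 3 (`COc1ccccc1C1C(C(=O)C(C)(C)C)=C(O)C(=O)N1c1ccc(-c2ccsc2)cc1`) gives 900 nM, the lowest of the three.

The next compound extends compound 3. Compound 4 (`C[S+]([O-])CCOc1ccccc1C1C(C(=O)C(C)(C)C)=C(O)C(=O)N1c1ccc(-c2ccsc2)cc1`) differs from it in one place: a group of 4 heavy atoms (2 carbon, 1 oxygen, 1 sulfur; no ring) in place of a hydrogen atom, on a saturated chain carbon bound to an oxygen on an aromatic ring.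

Among the measured compounds shown here, only one measured step bears on this change, and only loosely: a 33-fold lower number from compound 2 to compound 3 (1.52 log units; beyond the scatter). That large step comes from thiophen-3-yl in place of 1,2-oxazol-3-yl on an aromatic carbon, which is a different place from the one changed here. For the measured compounds named here, it shows that a single change in these compounds can move the number a long way, but no measured compound carries the entering group, so the step gives no direct guide to its effect. The other two compounds both stand higher than compound 3, which leaves more room upward within the measured range than downward.

A moderate step in this assay toward a higher number is therefore expected, smaller than the measured one, though this expectation is weakly founded. The expected change is a 4.4-fold higher number from compound 3 to compound 4 (0.65 log units; beyond the scatter). For compound 4 the estimated value is 4000 nM, with an expected range from 1000 nM to 20000 nM.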

Compound 4, solubility: > 50000 nM
Compound 4 ended at the assay's limit; the forecaster's own chance of this, stated with the estimate: 5%; middle value at least 12-fold (1.09 log units) from the limit.
By their numbers in this assay, from the lowest: compound 3; then compound 1; then compound 2. At a limit, above all of these: compound 4.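

Up to this point the only measured step lay at an aromatic carbon, where thiophen-3-yl replaced 1,2-oxazol-3-yl, with a 33-fold lower number from compound 2 to compound 3 (1.52 log units; beyond the scatter). Among these compounds, compound 4 gives the first reading at a second place, a saturated chain carbon bound to an oxygen on an aromatic ring, and in this assay the change gives an at least 55-fold higher number from compound 3 to compound 4 (1.74 log units; beyond the scatter), so this place also carries a large step, here with a group of 4 heavy atoms, no ring and no net charge entering in place of a hydrogen atom. The reading for compound 4 is a limit and not a number, and the full size of the step cannot be read from it: the limit of > 50000 nM in this assay, at which 1 of the 4 values shown sits.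

The compounds shown do not tell which part of the entering group goes with the step, and a sulfone, a hydroxyl or an amine at the end of the same chain would bear on that question. Going by these compounds, it also remains open whether the same group gives a step of this kind on compound 2, which carries 1,2-oxazol-3-yl in place of thiophen-3-yl.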